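The compounds below may be only part of what the source reports. "The series", "measured", "known", "first", "only" and "open" are said of these compounds alone.

Measured so far:
- compound 1 `Cn1c(CNC(=O)c2cccs2)nnc1SCC(=O)Nc1ccc(Cl)cc1`: 91400 nM
- compound 2 `Nc1ccc(SCC(=O)Nc2ccc3nc(NC(=O)c4ccc(C(F)(F)F)cc4)sc3c2)cc1`: 100 nM

In a functional assay on HCT-116 cells (Homo sapiens) for antiproliferative activity, read by MTT assay, with a stated time of 72 h (on this read-out lower numbers stand for stronger inhibition and higher numbers for weaker inhibition), compound 1 gives 91400 nM, while compound 2 gives 100 nM. Compound 2 thus holds the lowest number of the two, and the distance to compound 1 lies well beyond the scatter of the read-out. Going by the values given here, the two compounds share no single-point relationship, so no step between them is defined; their values show only that compound 2 is the far stronger inhibitor of the pair.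

Compound 3 `O=C(CSc1cccc(O)c1)Nc1ccc2nc(NC(=O)c3ccc(C(F)(F)F)cc3)sc2c1` has not yet been measured in this assay. It is built on the core of compound 2 and differs from it in one place:

3-hydroxyphenyl in place of 4-aminophenyl on a sulfur

Among the compounds with values here, no measured pair carries this kind of change, so there is no direct precedent for its size. The step expected here is a 2.0-fold higher number from compound 2 to compound 3 (0.30 log units; within the scatter), a modest shift toward a higher number that may not clear the scatter. Compound 3 is accordingly estimated at 200 nM, with a range from 50 nM to 1000 nM.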

Compound 3, half-maximal inhibitory concentration: 510 nM
Compound 3: middle estimate off by 2.6-fold (0.41 log units), on the low side; the range from low to high includes it.
By their numbers in this assay, from the lowest: compound 2; then compound 3; then compound 1.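

The position on the sulfur of the shared core responds to a change of aryl group in this assay, with 3-hydroxyphenyl in place of 4-aminophenyl giving a 5.1-fold higher number from compound 2 to compound 3 (0.71 log units; beyond the scatter). The two groups match in heavy-atom count and in their counts of hydrogen-bond donors and acceptors, so those counts alone do not set the value at this position. The step is modest in size, and compound 3 stays at 510 nM, which shows that this position can take a different aryl group without a loss on the scale of the full range seen in this series; no measurement shown here accounts for the step.

The change moves the substituent on the ring and exchanges amino for hydroxy in a single step, and the compounds shown do not separate these two differences; 4-hydroxyphenyl and 3-aminophenyl on the same sulfur would do so. Also open, on these data alone, is how much of the value depends on any substituent on this ring, a question that plain phenyl or 4-carboxyphenyl at this position would address.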